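Removing the pyrazole methyl from a compound at the assay limit

The source may report more compounds than this note shows. Statements on the series, on what has been measured and on what is new or still open speak of the compounds shown alone.

Measured compounds:
compound 1 `CN(CCN(C)C(=O)n1cc(C#N)cn1)Cc1ccc(OCc2ccccc2)cc1` in an assay on membranes from brain for binding affinity to Monoacylglycerol lipase ABHD6 (Mus musculus), read by fluorescence, with stated times of 1 h and 30 min (a higher number here means a weaker inhibitor, a lower number a stronger inhibitor), compound 1 gives 320 nM
compound 2 `Cc1cnn(C(=O)N2CCN(C(c3ccc(OCc4ccccc4)cc3)c3ccc(OCc4ccccc4)cc3)CC2)c1` in this assay compound 2 gives > 100000 nM

Compound 1 has a measured half-maximal inhibitory concentration in this assay. Compound 2 stands differently: the value reported for compound 2 in this assay is a limit of the assay and not a number, so one cannot say more than that compound 2 sits at that limit. That is what the record shows as the limit of > 100000 nM in this assay, at which 1 of the 2 values shown sits. Among the compounds with values here, no step between two measured compounds is available here, since compound 1 and compound 2 differ in more than one place.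

Compound 3 `O=C(N1CCN(C(c2ccc(OCc3ccccc3)cc2)c2ccc(OCc3ccccc3)cc2)CC1)n1cccn1` is the next compound, not yet measured in this assay. It differs from compound 2 by hydrogen in place of methyl on an aromatic carbon. Given that compound 2 is only known as a limit, the step from compound 2 to compound 3 in this assay is expected to bring no change beyond the scatter, so a number no higher from compound 2 to compound 3 (the limit leaves the size open) is the expected size. Compound 3 is therefore estimated at 100000 nM in this assay, within the range 20000 nM to 300000 nM, with a real chance that only a limit is reported again.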

Compound 3, half-maximal inhibitory concentration: > 100000 nM
Compound 3 gave a limit, no number; the forecaster's own chance of this, stated with the estimate: 70%; the middle value lies on the limit itself.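

In this assay compound 3 gives > 100000 nM, which is a limit of the assay and not a number. Within the data shown here, compound 2 sits at the same limit, so no step from compound 2 to compound 3 can be read. The compounds shown leave open whether hydrogen in place of methyl on this aromatic carbon changes inhibition at all.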